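The source may hold more compounds than are shown below. What is called first, only, known or untested is meant among the compounds shown, and "the series" means these compounds.

Compounds measured in an assay on isolated protein for inhibition of complement C1r subcomponent (Homo sapiens); a higher number here means a weaker inhibitor, a lower number a stronger inhibitor:
compound 1, `O=c1oc(-c2ccc(I)cc2)nc2ccccc12`: > 62500 nM
compound 2, `O=c1oc(-c2ccccc2I)nc2ccc(Cl)cc12`: 7800 nM
compound 3, `COc1ccc2nc(-c3ccccc3I)oc(=O)c2c1`: > 62500 nM

Of these three, only compound 2 gives a number in this assay. For compound 1 the reading is a limit of the assay rather than a number. For compound 3 the reading is likewise a limit of the assay, so compound 3 stands at the weak end of what this assay can report. Two of the three readings sit at the limit of > 62500 nM in this assay, at which 2 of the 3 values shown sit. Among the compounds with values here, the only step that can be read between measured compounds is an at least 8.0-fold higher number from compound 2 to compound 3 (0.90 log units; beyond the scatter), which runs from a number up to a limit.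

Compound 4, `COc1cc2nc(-c3ccccc3I)oc(=O)c2cc1OC`, differs from compound 3 by methoxy in place of hydrogen on an aromatic carbon. Within the data shown here, no measured step bears directly on this change, since the one step available concerns a different position and a different group. With compound 3 already at the limit, compound 4 is expected to remain there, and the estimated step is a step that the limit leaves unreadable from compound 3 to compound 4, most likely no change beyond the scatter. For compound 4 the estimated value in this assay is 70000 nM, with a range from 20000 nM to 250000 nM.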

Compound 4, half-maximal inhibitory concentration: > 62500 nM
Compound 4: only a limit was reported (the forecaster's own chance of this, stated with the estimate: 80%); the middle value lies beyond the limit too.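

In this assay compound 4 gives > 62500 nM, which is a limit of the assay and not a number. Compound 3 also reads as a limit, so no step can be read from compound 3 to compound 4: the limit of > 62500 nM in this assay, at which 3 of the 4 values shown sit.

The compounds shown leave open whether methoxy in place of hydrogen at this place changes the inhibition at all.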